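A few compounds are considered here, and "the series" means these few. Any claim that something is new, unique, unknown or untested is made for them only; others in the source may bear on it.

Compound 1 `Brc1cncc(N2CC[C@H]3CN[C@H]3C2)c1` gives 150 nM in a functional assay on HEK293 cells for agonist activity at Neuronal acetylcholine receptor; alpha4/beta2 (Homo sapiens), read by FLIPR; a higher number here means that more compound is needed for the effect, a lower number that less compound is needed. Compound 2 `COc1cc(N2C[C@@H]3CCNC[C@@H]32)cnc1Br` gives 1690 nM in this assay. Compound 3 `COc1cc(N2C[C@H]3CCNC[C@H]32)cnc1Br` gives 200 nM in this assay.

Among the three measured compounds, compound 3 stands second highest; its nearest neighbour is compound 1, which lies within the scatter of it, and its furthest is compound 2. Going by the values given here, the only step that joins two measured compounds runs an 8.5-fold lower number from compound 2 to compound 3 (0.93 log units; beyond the scatter), and that step rests on the fact that compounds 2 and 3 differ only in the configuration as drawn: the two are mirror images and nothing else changes.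

Compound 4 `N#Cc1cc(N2C[C@H]3CCNC[C@H]32)cnc1Br` differs from compound 3 by cyano in place of methoxy on an aromatic carbon, with the configuration of compound 3 kept. Among the compounds with values here, no measured step among the three compounds exchanges one group for another on the aromatic ring, so the data give no step to size this change by. The expectation therefore falls back on compound 3 itself: compound 4 is estimated at 300 nM, with a range from 70 nM to 1500 nM, which means an expected step of a 1.5-fold higher number from compound 3 to compound 4 (0.18 log units; within the scatter).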

Compound 4, half-maximal effective concentration: 172 nM
Compound 4: middle estimate off by 1.7-fold (0.24 log units), on the high side; measured number inside the range.
By their numbers in this assay, from the lowest: compounds 1, 4 and 3 (each within the scatter of the next); then compound 2.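

Cyano in place of methoxy on this aromatic carbon, ortho to a bromo group and two atoms from the ring nitrogen, gives a 1.2-fold lower number from compound 3 to compound 4 (0.07 log units; within the scatter) in this assay. This is the first exchange of one group for another on the aromatic ring among the compounds shown, and with the configuration of compound 3 kept, the position takes either group with no difference beyond the scatter. Nothing measured here speaks to why these two groups read alike.

As far as these compounds go, it remains open whether a different kind of group at this position, such as an amine, a carboxylic acid or a longer alkyl chain, would read the same way. Also open, from the compounds shown here alone, is whether cyano in the mirror-image configuration would show a gap like an 8.5-fold lower number from compound 2 to compound 3 (0.93 log units; beyond the scatter).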